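Methyl in place of chloro: expectation for compound 4

The compounds below may be only part of what the source reports. "The series", "measured", "known", "first", "only" and "open" are said of these compounds alone.

In an ADME assay on CCRF-CEM cells (Homo sapiens) for antiproliferative activity, with a stated time of 48 h (on this read-out lower numbers stand for stronger inhibition and higher numbers for weaker inhibition), compound 1 (`Nc1ccc(/C=C/C(=O)c2ccc(F)cc2)cc1`) gives 39000 nM, compound 2 (`Nc1ccc(/C=C/C(=O)c2ccc(Cl)cc2)cc1`) gives 21000 nM and compound 3 (`Nc1ccc(/C=C/C(=O)c2ccc(Cl)c(Cl)c2)cc1`) gives 15000 nM. Compound 2 stands within the scatter of both other compounds, so its number offers no firm ranking. Compound 4 (`Cc1ccc(C(=O)/C=C/c2ccc(N)cc2)cc1`) is still unmeasured and carries methyl in place of chloro on an aromatic carbon, relative to compound 2: methyl in place of chloro on an aromatic carbon.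

Among the compounds with values here, two measured steps bear on this change. The exchange of fluoro for chloro gave a 1.9-fold lower number from compound 1 to compound 2 (0.27 log units; within the scatter), and chloro in place of hydrogen gave a 1.4-fold lower number from compound 2 to compound 3 (0.15 log units; within the scatter). Within the data shown here, neither step leaves the scatter, and no measured compound yet carries methyl. No step beyond the scatter is therefore expected in this assay, with at most a slight drift towards a higher number. The expected step is a 1.3-fold higher number from compound 2 to compound 4 (0.12 log units; within the scatter). For compound 4 the estimated value is 28000 nM, with an expected range from 14000 nM to 55000 nM.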

Compound 4, half-maximal inhibitory concentration: 31000 nM
Beside the measured number, compound 4's estimate is 1.1-fold (0.04 log units) below it, and the stated range covers the measured number.
By their numbers in this assay, from the lowest: compounds 3, 2, 4 and 1 (each within the scatter of the next, the first and the last beyond it).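

Methyl in place of chloro gives a 1.5-fold higher number from compound 2 to compound 4 (0.17 log units; within the scatter) in this assay and methyl in place of fluoro gives a 1.3-fold lower number from compound 1 to compound 4 (0.10 log units; within the scatter) in the same read-out. The earlier compounds shown here carried only halogens on this aromatic carbon, para to a large group, whereas compound 4 shows that a carbon group of one heavy atom also stays within the scatter of both single-halogen compounds. No supporting data bear on why these numbers fall where they do.

From the compounds shown here alone, it remains open whether a methoxy group, an amine, a carboxylic acid or a longer chain at this position would give a step beyond the scatter. Also open, going by these compounds, is how compound 4 would respond to a chloro group added on the same ring, the change that links compound 2 to compound 3.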